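A few compounds are considered here, and "the series" means these few. Any claim that something is new, unique, unknown or untested is made for them only; others in the source may bear on it.

Measured in a functional assay on 4T1 cells (Homo sapiens) for cytotoxicity, read by MTT assay, with a stated time of 48 h; a higher number here means a weaker inhibitor, a lower number a stronger inhibitor:
Compound 1 `CCn1c(/C=C2/C(=O)Nc3ccc(F)cc32)nc2ccccc21`: > 50000 nM, a limit of the assay
Compound 2 `CCn1c(/C=C2/C(=O)Nc3ccc(C)cc32)nc2ccccc21`: 39400 nM
Compound 3 `CC(C)n1c(/C=C2/C(=O)Nc3ccc(Cl)cc32)nc2ccccc21`: 35700 nM

Compound 3, at 35700 nM, sits within the scatter of compound 2 at 39400 nM. Compound 4 `CCn1c(/C=C2/C(=O)Nc3ccc(Cl)cc32)nc2ccccc21` differs from compound 3 by one change, isopropyl to ethyl: hydrogen in place of methyl on a saturated chain carbon bound to an aromatic nitrogen and a saturated chain carbon. Going by the values given here, the one measured step, an at least 1.2-fold lower number from compound 1 to compound 2 (0.10 log units; that floor lies within the scatter), is methyl in place of fluoro on an aromatic carbon, a different change from this one. Compound 1 stands at the limit of > 50000 nM in this assay, at which 1 of the 3 values shown sits. Among the compounds with values here, no measured pair varies this chain alone, so no shift beyond the scatter is expected in this assay. The expected step, a 1.1-fold higher number from compound 3 to compound 4 (0.03 log units; within the scatter), is small. For compound 4 the estimate is 38000 nM, with an expected range of 20000 nM to 60000 nM.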

Compound 4, half-maximal inhibitory concentration: > 50000 nM
Compound 4: only a limit was reported; the forecaster's own chance of this, stated with the estimate: 20%; at least 1.3-fold (0.11 log units) between middle value and limit.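

The isopropyl to ethyl change now has a measured pair of its own, which gives an at least 1.4-fold higher number from compound 3 to compound 4 (0.14 log units; that floor lies within the scatter) in this assay. Chloro in place of methyl on an aromatic carbon gives an at least 1.2-fold higher number from compound 2 to compound 4 (0.10 log units; that floor lies within the scatter), so both steps are floors only, and the steps that join two limits cannot be read. Compound 4 gives only a limit of the assay, and the series now rests on it as much as on measured numbers: the limit of > 50000 nM in this assay, at which 2 of the 4 values shown sit.

On these data alone, it remains open how a longer chain in place of ethyl would read in this assay. An amine in place of chloro on the aromatic carbon is equally unresolved.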